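Dropping Both Halogens From the Benzyl Group

The source may report more compounds than this note shows. Statements on the series, on what has been measured and on what is new or still open speak of the compounds shown alone.

Three measured compounds share one core and differ only in the group on the saturated chain carbon bound to a sulfur. Compound 1 `Cc1cc(N2CC[C@@H](C)[C@@H](N(C)c3ncnc4[nH]ccc34)C2)n2nc(SCc3ccc(Cl)cc3)nc2n1` carries 4-chlorophenyl there; in a toxicity assay on GES1 cells (Homo sapiens) for inhibition, read by MTT assay, with a stated time of 72 h (on this read-out higher numbers stand for weaker inhibition and lower numbers for stronger inhibition), compound 1 gives > 100000 nM, which is a limit of the assay rather than a number. Compound 2 `Cc1cc(N2CC[C@@H](C)[C@@H](N(C)c3ncnc4[nH]ccc34)C2)n2nc(SCc3ccc(Br)cc3)nc2n1` carries 4-bromophenyl, and in this assay compound 2 gives 55600 nM. Compound 3 `Cc1cc(N2CC[C@@H](C)[C@@H](N(C)c3ncnc4[nH]ccc34)C2)n2nc(SCc3ccc(F)c(Cl)c3)nc2n1` carries 3-chloro-4-fluorophenyl; in this assay compound 3 gives > 100000 nM, again a limit of the assay and not a number. Compound 3 thus stands at the limit of > 100000 nM in this assay, at which 2 of the 3 values shown sit. The steps toward it read a step that the two limits leave unreadable from compound 1 to compound 3 and an at least 1.7-fold higher number from compound 2 to compound 3 (0.25 log units; that floor lies within the scatter). Compound 4 `Cc1cc(N2CC[C@@H](C)[C@@H](N(C)c3ncnc4[nH]ccc34)C2)n2nc(SCc3ccccc3)nc2n1` has not yet been measured; it differs from compound 3 by phenyl in place of 3-chloro-4-fluorophenyl on a saturated chain carbon bound to a sulfur. Every measured step here either stays within the scatter or cannot be read, so no step beyond the scatter is expected in this assay from this change. The step expected is a number no higher from compound 3 to compound 4 (the limit leaves the size open). Compound 4 is therefore expected to give about 100000 nM in this assay, with a range from 40000 nM to 300000 nM.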

Compound 4, half-maximal inhibitory concentration: 67200 nM
Beside the measured number, compound 4's estimate is 1.5-fold (0.17 log units) above it; low and high end bracket the measured number.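

With phenyl in this place, the benzyl group carries no halogen at all, and in this assay removing both halogens gives an at least 1.4-fold lower number from compound 3 to compound 4 (0.17 log units; that floor lies within the scatter). Removing the single halogen gives a 1.2-fold higher number from compound 2 to compound 4 (0.08 log units; within the scatter) and an at least 1.4-fold lower number from compound 1 to compound 4 (0.17 log units; that floor lies within the scatter), so no step to compound 4 is shown to lie beyond the scatter, and the halogens shown are not needed for the read-out to stay this high. Two of these steps give only a floor, since compound 1 and compound 3 each stand at a limit of the assay rather than a number: the limit of > 100000 nM in this assay, at which 2 of the 4 values shown sit.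

From the compounds shown here alone, how far those two compounds truly lie from compound 4 remains open. Also open, going by these compounds, is whether an amine or a carboxylic acid on the phenyl ring would bring a step beyond the scatter.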